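The source may report more compounds than this note shows. Statements on the series, on what has been measured and on what is new or still open speak of the compounds shown alone.

Measured compounds:
compound 1, `CN(CC1CCC/C(=C\c2ccc(S(C)(=O)=O)cc2)C1=O)c1ccccc1`, 51.1%
compound 2, `Cc1cccc(N(C)CC2CCC/C(=C\c3ccc(S(C)(=O)=O)cc3)C2=O)c1`, 36.2%
compound 3, `COc1ccc(C2(O)/C(=C/c3ccccc3)CCCC2CN(C)c2ccccc2)cc1`, 38.3%

In a functional assay on the whole organism (strain Wistar) for inhibition, with Rattus norvegicus as the target, read by paw edema, with stated times of 1 h and 3 h, at a dose of 200 mg/kg by the oral route (on this read-out lower numbers stand for less inhibition and higher numbers for more inhibition at the one dose given (going by the name of the read-out)), compound 1 gives 51.1%, compound 2 gives 36.2% and compound 3 gives 38.3%. Compound 2 differs from compound 1 by methyl in place of hydrogen on an aromatic carbon, and this made a number 14.9 percentage points lower from compound 1 to compound 2 (beyond the scatter). Compound 4, `COc1ccc(C2(O)/C(=C/c3ccc(C)cc3)CCCC2CN(C)c2ccccc2)cc1`, is not yet measured; it differs from compound 3 by methyl in place of hydrogen on an aromatic carbon. The difference between the core of compound 3 and the core of compound 1 is not broken down here. The two changes are the same kind of change, but the methyl enters meta to a large group in compound 2 and para to a large group in compound 4, and on a different core. Because of a number 14.9 percentage points lower from compound 1 to compound 2 (beyond the scatter) a modest lowering is expected for compound 4, estimated as a number 8.3 percentage points lower from compound 3 to compound 4 (within the scatter), with less weight given the changed place. Compound 4 is expected to give about 30%, between 18% and 42%.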

Compound 4, a percentage reported as inhibition, in the whole organism at one dose (the size of the read-out at that dose, not a potency): 17%
Compound 4: the middle estimate sits 13 percentage points above what was measured; measured number below the stated range.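

In this assay, methyl in place of hydrogen on an aromatic carbon gave a number 21.3 percentage points lower from compound 3 to compound 4 (beyond the scatter), so the lowering seen on the core of compound 1 also appeared on the core of compound 3. The two steps do not differ beyond what repeated measurement would produce: the same change on two cores in this assay, a number 14.9 percentage points lower (beyond the scatter) from compound 1 to compound 2 and a number 21.3 percentage points lower (beyond the scatter) from compound 3 to compound 4, 6.4 percentage points apart, within the scatter of two such steps. This rests on a single pair for each core, with the methyl in a different place on the ring, so it shows that the direction carried over here but not that it would hold on other cores or at other places.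

The compounds shown leave open whether the lowering is particular to methyl. Chlorine, an ethyl group or a carboxylic acid at that place could behave differently.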